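Carbamate in Place of a Benzyl Ether on a Shared Core

The source may hold more compounds than are shown below. What is called first, only, known or untested is meant among the compounds shown, and "the series" means these compounds.

Compound 1 `CC(C)=CCC1Cc2c(OCc3ccccc3)cc(=O)n(CCCO)c2CC1(C)C` carries a benzyl group on the ring oxygen of the shared core. In a functional assay on PANC-1 cells (Homo sapiens) for inhibition, read by MTT assay, with a stated time of 24 h, tested at 10 uM (on this read-out higher numbers stand for more inhibition at the one concentration tested (going by the name of the read-out) and lower numbers for less inhibition), compound 1 gives -0.3%, the lowest of the two numbers measured. Among the compounds with values here, compound 2 `CC(C)=CCC1Cc2c(OC(=O)Nc3ccc(F)cc3F)cc(=O)n(CCCO)c2CC1(C)C` gives 69.7%, and the step of a number 70 percentage points higher from compound 1 to compound 2 (beyond the scatter) is the only measured step that bears on what follows. Compound 3 `CC(C)=CCC1Cc2c(OC(=O)Nc3ccc(Cl)c(Cl)c3)cc(=O)n(CCCO)c2CC1(C)C` differs from compound 1 by (3,4-dichlorophenyl)carbamoyl in place of benzyl on an oxygen on an aromatic ring. Since compound 2 showed a large rise after a change of the same kind, a step of comparable size and direction is expected: a number 60.3 percentage points higher from compound 1 to compound 3 (beyond the scatter). Compound 3 is therefore estimated at 60%, within 35% to 85%.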

Compound 3, a percentage reported as inhibition, at one concentration (the size of the read-out at that concentration, not a potency): 61.4%
Beside the measured number, compound 3's estimate is 1.4 percentage points below it; the range from low to high includes it.
By their numbers in this assay, from the lowest: compound 1; then compounds 3 and 2 (each within the scatter of the next).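

In this assay, the large rise seen with the first carbamate is not confined to one aryl group, as a second aryl carbamoyl on the same oxygen gives a number 61.7 percentage points higher from compound 1 to compound 3 (beyond the scatter). Exchanging 2,4-difluorophenyl for 3,4-dichlorophenyl on the amide-type nitrogen gives a number 8.3 percentage points lower from compound 2 to compound 3 (within the scatter), so this assay does not separate the two aryl groups. No evidence on the origin of these steps is available. The compounds shown leave open whether the aryl ring is needed at all, which an ethyl or unsubstituted phenyl carbamoyl would address. They also leave open whether the amide hydrogen matters, which an N-methyl carbamate would address.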